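A few compounds are considered here, and "the series" means these few. Any claim that something is new, unique, unknown or untested is made for them only; others in the source may bear on it.

Compound 1 `N[C@H]1CC[C@H](Nc2c(C(=O)NCc3ccccn3)nc(Br)c3cccnc23)CC1`: in a functional assay on HEY cells (Homo sapiens) for cytotoxicity, read by MTT assay, with a stated time of 72 h (a lower number here means a stronger inhibitor, a higher number a weaker inhibitor), compound 1 gives > 20000 nM, a limit of the assay rather than a number.
Compound 2 `N[C@H]1CC[C@H](Nc2c(C(=O)NCc3ccco3)nc(Br)c3cccnc23)CC1`: in this assay compound 2 gives > 10000 nM, again a limit and not a number.

For the measured compounds named here, the single measured step, a step that the two limits leave unreadable from compound 1 to compound 2, cannot be read, since both of its ends sit at limits (the limit of > 10000 nM in this assay, at which 1 of the 2 values shown sits, and (the limit of > 20000 nM in this assay, at which 1 of the 2 values shown sits)). Compound 2 therefore stands at a limit only, with no measured potency that would place it against another compound.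

Compound 3 `N[C@H]1CC[C@H](Nc2c(C(=O)Nc3ccccc3)nc(Br)c3cccnc23)CC1` differs from compound 2 in one place: phenyl in place of (furan-2-yl)methyl on an amide-type nitrogen. Going by the values given here, no measured step covers this change, and the only step measured, from another change, is unreadable. Nothing here points to a direction or size of change in this assay; the expectation is simply that compound 3 also reaches only a limit. Compound 3 is thus estimated at 20000 nM, within 5000 nM to 80000 nM. For compound 3 the expected step is a step that the limit leaves unreadable from compound 2 to compound 3.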

Compound 3, half-maximal inhibitory concentration: 1000 nM
Estimate against measurement, compound 3: 20-fold (1.30 log units) above; measured number below the stated range.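

For the compounds shown here, compound 3 is the first compound here with a real number in this assay, which shows that the group on the amide-type nitrogen can matter in this assay: phenyl in place of (furan-2-yl)methyl gives an at least 10-fold lower number from compound 2 to compound 3 (1.00 log units; beyond the scatter), and phenyl in place of (pyridin-2-yl)methyl gives an at least 20-fold lower number from compound 1 to compound 3 (1.30 log units; beyond the scatter). The first of these sizes is only a minimum, because compound 2 stands at a limit and not at a number: the limit of > 10000 nM in this assay, at which 1 of the 3 values shown sits. The second is also a minimum, because compound 1 likewise stands at a limit: the limit of > 20000 nM in this assay, at which 1 of the 3 values shown sits.

The compounds shown do not separate the two things that change together, the ring itself and the loss of the chain carbon that held it on the nitrogen. A benzyl group on the same nitrogen, with the carbon-only ring and the chain carbon together, would tell these two apart.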